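Replacing the Aryl Group on the Ring Nitrogen

The source may hold more compounds than are shown below. What is called first, only, known or untested is meant among the compounds shown, and "the series" means these compounds.

Among the measured compounds shown here, in an assay on isolated protein for inhibition of DNA nucleotidylexotransferase (Homo sapiens), read by scintillation counting, with a stated time of 10 min (on this read-out lower numbers stand for stronger inhibition and higher numbers for weaker inhibition), compound 3 `O=C(/C=C/c1cn(-c2ccc(Cl)cc2)c2ccccc12)CC(=O)C(=O)O` gives 31 uM, the only numerical value in this small set. Compound 1 `CCOC(=O)C(=O)CC(=O)/C=C/c1cn(-c2ccccc2)c2ccccc12` reaches only the assay limit of > 40 uM. Compound 2 `CCOC(=O)C(=O)CC(=O)/C=C/c1cn(-c2ccc(Cl)cc2)c2ccccc12` likewise stops at the assay limit of > 40 uM. For the measured compounds named here, the one readable comparison is an at least 1.2-fold lower number from compound 2 to compound 3 (0.11 log units; that floor lies within the scatter). The other comparison, a step that the two limits leave unreadable from compound 1 to compound 2, cannot be sized because both ends sit at the limit of > 40 uM in this assay, at which 2 of the 3 values shown sit. Compound 4 `CN(C)C(=O)Cn1cc(/C=C/C(=O)CC(=O)C(=O)O)c2ccccc21` differs from compound 3 by (dimethylcarbamoyl)methyl in place of 4-chlorophenyl on an aromatic nitrogen. Going by the values given here, no measured step touches the group on this ring nitrogen, so no shift beyond the scatter is expected, and the estimate for compound 4 is 40 uM, within a range from 15 uM to 120 uM, which means an expected step of a 1.3-fold higher number from compound 3 to compound 4 (0.11 log units; within the scatter).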

Compound 4, concentration for 50% inhibition: 8.9 uM
Estimate against measurement, compound 4: 4.5-fold (0.65 log units) above, and the stated range ends above it.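

The group on the ring nitrogen need not be an aryl group. In this assay, among the compounds shown here, (dimethylcarbamoyl)methyl in place of 4-chlorophenyl gives a 3.5-fold lower number from compound 3 to compound 4 (0.54 log units; beyond the scatter), so a group with no ring is accepted here and inhibition improves, the first change in this set to pass beyond the scatter. Nothing measured here explains that gain.

From the compounds shown here alone, it remains open whether the gain depends on the amide carbonyl or simply on the loss of the 4-chlorophenyl ring. A plain methyl, a longer alkyl chain or a primary amine on this nitrogen would help separate those two readings.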